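The compounds below may be only part of what the source reports. "The series", "measured", "known", "first", "only" and "open" are said of these compounds alone.

Working notes on the series.

Three compounds have numbers in a functional assay on cells (Lymphocyte, Homo sapiens), read by trypan blue exclusion, with a stated time of 16 h, tested at 2.5 uM; a higher number here means a stronger effect of the compound at the concentration tested, a lower number a weaker effect. Compound 1 `CCCCCCCCCCCCCCCCc1c(C)c(N(C)C)nc(C)c1O` gives 84% in this assay. Compound 2 `CCCCCCCCCCc1c(C)c(N(C)C)nc(C)c1O` gives 86% in this assay. Compound 3 `CCCCCCCCCCc1nc(N(C)C)c(C)c(C)c1O` gives 87% in this assay. Compound 2 stands second highest of the three numbers; the gap to compound 3 and the gap to compound 1 both lie within the scatter, so the three read as one level.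

Compound 1 and compound 2 differ in one place: hydrogen in place of hexyl on a saturated chain carbon, ten or more bonds along the chain from an aromatic carbon, and the step is a number 2 percentage points higher from compound 1 to compound 2 (within the scatter).

Compound 4 `CCCCCCCCCCCCCCCCCCCc1c(C)c(N(C)C)nc(C)c1O` has not yet been measured in this assay. Against compound 2 the change is nonyl in place of hydrogen on a saturated chain carbon, ten or more bonds along the chain from an aromatic carbon. Within the data shown here, the one measured step that bears on this is the one from compound 1 to compound 2, which also swaps a hydrogen for an alkyl group at the same kind of place and stays within the scatter. The expected step from compound 2 to compound 4 is therefore a number 1 percentage points lower from compound 2 to compound 4 (within the scatter), none beyond the scatter. Compound 4 is estimated at 85%, with a range of 72% to 94%.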

Compound 4, a percentage reported as activity, at one concentration (the size of the read-out at that concentration, not a potency): 87%
Estimate against measurement, compound 4: 2 percentage points below; low and high end bracket the measured number.
By their numbers in this assay, from the lowest: compounds 1, 2, 3 and 4 (each within the scatter of the next).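

Nonyl in place of hydrogen on a saturated chain carbon gives a number 1 percentage points higher from compound 2 to compound 4 (within the scatter) and propyl in place of hydrogen at the same kind of place gives a number 3 percentage points higher from compound 1 to compound 4 (within the scatter) as the second new reading. Where one step along the chain stood before, compounds 1, 2 and 4 now supply three, and in this assay none of them separates these compounds, so at this position the added chain length leaves the read-out at one level. No supporting measurement bears on this result.

From the compounds shown here alone, whether a much shorter chain such as ethyl would hold this level stays open, as does the effect of a chain ending in a carboxylic acid or an amine. A single concentration also leaves open whether compounds 1, 2 and 4 would still read alike at lower concentrations.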